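Halogenated aryl hydrazones: a hydroxy-chloro variant

The compounds below may be only part of what the source reports. "The series", "measured", "known", "first", "only" and "open" are said of these compounds alone.

Measured compounds:
- compound 1, `O=C(CSc1nnc(-c2ccncc2)o1)N/N=C/c1ccc(Br)cc1`: 24500 nM
- compound 2, `O=C(CSc1nnc(-c2ccncc2)o1)N/N=C/c1cccc(F)c1`: 27500 nM
- compound 3, `O=C(CSc1nnc(-c2ccncc2)o1)N/N=C/c1ccccc1F`: 24000 nM

In a functional assay on BGC-823 cells (Homo sapiens) for cytotoxicity, read by MTT assay, with a stated time of 48 h (on this read-out higher numbers stand for weaker inhibition and lower numbers for stronger inhibition), compound 3 gives the lowest of the three numbers, but its steps to the others lie within the scatter: a 1.0-fold lower number from compound 1 to compound 3 (0.01 log units; within the scatter) and a 1.1-fold lower number from compound 2 to compound 3 (0.06 log units; within the scatter). The three compounds are therefore indistinguishable on this read-out.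

Compound 4, `O=C(CSc1nnc(-c2ccncc2)o1)N/N=C/c1cc(Cl)ccc1O`, is not yet measured. It differs from compound 3 by 5-chloro-2-hydroxyphenyl in place of 2-fluorophenyl on a carbon with a double bond to nitrogen. The measured steps that bear on this change are those that swap one aryl group for another on the same carbon: a 1.1-fold higher number from compound 1 to compound 2 (0.05 log units; within the scatter), a 1.0-fold lower number from compound 1 to compound 3 (0.01 log units; within the scatter) and a 1.1-fold lower number from compound 2 to compound 3 (0.06 log units; within the scatter). Among the measured compounds shown here, all of them are within the scatter, so no step beyond the scatter is expected in this assay for compound 4 either, though no measured compound carries a hydroxyl or a chlorine in this position, so the expectation rests on a short series. Compound 4 is estimated at 24000 nM in this assay, with a range from 9000 nM to 60000 nM, a step of no change at the digits printed from compound 3 to compound 4 (within the scatter) that is expected to stay within the scatter.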

Compound 4, half-maximal inhibitory concentration: 5470 nM
Compound 4: middle estimate off by 4.4-fold (0.64 log units), on the high side; measured number outside the range, below it.
By their numbers in this assay, from the lowest: compound 4; then compounds 3, 1 and 2 (each within the scatter of the next).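

In this assay, the aryl group on a carbon with a double bond to nitrogen proves not to be indifferent: 5-chloro-2-hydroxyphenyl gives a 4.4-fold lower number from compound 3 to compound 4 (0.64 log units; beyond the scatter) and a 5.0-fold lower number from compound 2 to compound 4 (0.70 log units; beyond the scatter) and a 4.5-fold lower number from compound 1 to compound 4 (0.65 log units; beyond the scatter), whereas the swaps among the three halogenated phenyl groups all stayed within the scatter. Compound 4 is thus the only one of the four set apart from all the others, and its group also carries a hydrogen-bond donor and a hydrogen-bond acceptor, which 2-fluorophenyl lacks. Nothing available here accounts for this step.

In compound 4 the hydroxyl and the chlorine enter together, so a phenyl group carrying only one of them would be needed to tell their shares apart. As far as these compounds go, whether a methoxy group or an amine could stand in for the hydroxyl and keep the step also remains open.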